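The compounds below may be only part of what the source reports. "The series", "measured", "known", "first", "only" and "open" are said of these compounds alone.

Compound 1, `COc1ccc(-c2[nH]c3ccccc3c2/C=C(\C#N)S(=O)(=O)c2ccccc2)cc1`: 1900 nM
Compound 2, `COc1ccc2[nH]c(-c3ccccc3)c(C=C(C#N)C#N)c2c1`: 7400 nM
Compound 3, `CCOC(=O)C(=Cc1c(-c2ccccc2)[nH]c2ccccc12)C(=O)OCC`: 4400 nM

In a functional assay on ACHN cells (Homo sapiens) for inhibition, read by sulforhodamine B assay, with a stated time of 48 h (a lower number here means a stronger inhibitor of growth, a higher number a weaker inhibitor of growth), compound 1 stands lowest of the three numbers. Its nearest neighbour is compound 3, which gives 4400 nM, a number higher than that of compound 1 by more than the usual scatter. Furthest away is compound 2, which gives 7400 nM, higher again beyond the scatter. Compound 1 therefore gives the strongest growth inhibition of the three measured compounds in this assay.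

The unmeasured compound 4, `COc1ccc(-c2[nH]c3ccc(OC)cc3c2/C=C(\C#N)S(=O)(=O)c2ccccc2)cc1`, keeps the whole of compound 1 and differs from it in a single place: methoxy in place of hydrogen on an aromatic carbon. For the measured compounds named here, no pair of measured compounds shows this one change on its own; compound 2 and compound 3 each differ from compound 1 in more than one place, so their numbers cannot be read as a guide to the methoxy group alone. With nothing in the measured set to anchor the step, the writer expects the change from compound 1 to compound 4 in this assay to be small, a 1.1-fold lower number from compound 1 to compound 4 (0.05 log units; within the scatter), with no clear direction and quite possibly within the scatter. On that basis compound 4 is estimated at 1700 nM in this assay, with a range from 700 nM to 4500 nM.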

Compound 4, concentration for 50% growth inhibition: 1800 nM
Compound 4: the middle estimate sits 1.1-fold (0.02 log units) below what was measured; measured number inside the range.
By their numbers in this assay, from the lowest: compounds 4 and 1 (each within the scatter of the next); then compounds 3 and 2 (each within the scatter of the next).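

Methoxy in place of hydrogen on an aromatic carbon now has a direct reading in this assay, which the earlier compounds could not give, as each of them differs from compound 1 in more than one place. For the compounds shown here, the single step, a 1.1-fold lower number from compound 1 to compound 4 (0.02 log units; within the scatter), shows that at this position, on the six-membered aromatic ring of carbon only that belongs to the fused system of two rings, the added methoxy leaves compound 4 indistinguishable from compound 1 in this measure of growth inhibition. No measurement shown here offers an explanation for that result, whether from the target, the cells or the compounds themselves.

On these data alone, this single step describes only hydrogen and methoxy at one position, so it remains open whether an amine, a carboxylic acid, a fluorine atom or a longer chain such as butoxy on the same aromatic carbon would also keep the number within the scatter of compound 1. As far as these compounds go, it also remains open whether a methoxy group on other aromatic carbons of the shared core would give the same reading.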